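From Carbonyloxy to Benzyl on the Shared Core

The source may hold more compounds than are shown below. What is called first, only, known or untested is meant among the compounds shown, and "the series" means these compounds.

In a functional assay on HeLa cells (Homo sapiens) for inhibition, read by MTT assay, with a stated time of 72 h (a lower number here means a stronger inhibitor, a higher number a weaker inhibitor), compound 3 `CC(C)=CCC/C(C)=C/C[C@@H]1C[C@]2(CC=C(C)C)C(=O)[C@@](CC=C(C)C)(C(=O)C(OC(=O)c3ccc(O)c(O)c3)=C2O)[C@@]1(C)CCC=C(C)C` gives 15100 nM. Compound 1 `CC(=O)Oc1cc(C(=O)C2=C(O)[C@]3(CC=C(C)C)C[C@@H](C/C=C(\C)CCC=C(C)C)[C@](C)(CCC=C(C)C)[C@](CC=C(C)C)(C2=O)C3=O)ccc1O` gives 8970 nM and compound 2 `CC(C)=CCC/C(C)=C/C[C@@H]1C[C@]2(CC=C(C)C)C(=O)[C@@](CC=C(C)C)(C(=O)C(C(=O)c3ccc(O)c(OC(=O)CCCC[C@@H]4SCC5NC(=O)NC54)c3)=C2O)[C@@]1(C)CCC=C(C)C` gives 12700 nM. These three values all lie within the scatter of one another, so compound 3 cannot be separated from the other two.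

Compound 4 `CC(C)=CCC/C(C)=C/C[C@@H]1C[C@]2(CC=C(C)C)C(=O)[C@@](CC=C(C)C)(C(=O)C(Cc3ccc(O)c(O)c3)=C2O)[C@@]1(C)CCC=C(C)C` carries 3,4-dihydroxybenzyl in place of ((3,4-dihydroxyphenyl)carbonyl)oxy on a double-bonded ring carbon.

Within the data shown here, no measured step makes this same exchange, so the evidence is indirect. Among the measured compounds shown here, the closest guide is the one measured step, a 1.4-fold higher number from compound 1 to compound 2 (0.15 log units; within the scatter), where a large group replaces a hydrogen atom on a saturated chain carbon bound to a carbonyl carbon. Even that sizeable addition leaves the number within the scatter. A similarly small change therefore seems likely here, with no firm direction. The expected change is a 1.3-fold lower number from compound 3 to compound 4 (0.10 log units; within the scatter), which would not stand beyond the scatter. For compound 4 the estimated value in this assay is 12000 nM, with an expected range from 5500 nM to 26000 nM.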

Compound 4, half-maximal inhibitory concentration: > 20000 nM
Compound 4: no number, only a limit (the forecaster's own chance of this, stated with the estimate: 10%); at least 1.6-fold (0.22 log units) between middle value and limit.
By their numbers in this assay, from the lowest: compounds 1, 2 and 3 (each within the scatter of the next). At a limit, above all of these: compound 4.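

In this assay compound 4 gives > 20000 nM, which is a limit of the assay and not a number. This is the first change shown at this double-bonded ring carbon, and replacing ((3,4-dihydroxyphenyl)carbonyl)oxy with 3,4-dihydroxybenzyl gives an at least 1.3-fold higher number from compound 3 to compound 4 (0.12 log units; that floor lies within the scatter), so the exchange brings no lower number, though its floor does not separate the two compounds. The size of the step stays unknown because the reading stops at a limit: the limit of > 20000 nM in this assay, at which 1 of the 4 values shown sits.

The compounds shown leave open whether keeping the 3,4-dihydroxyphenyl ring matters at this carbon, or whether the group joining that ring to the core decides the outcome. They also leave open how this assay would read with a carboxylic acid, an amine or a longer chain at the same place.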